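A few compounds are considered here, and "the series" means these few. Any claim that something is new, unique, unknown or untested is made for them only; others in the source may bear on it.

Compound 1 `COc1ccc(C(=O)/C=C/c2cc(-c3cc(OC)c(OC)c(OC)c3)n[nH]2)cc1OC` is tested in a functional assay on COLO 205 cells (Homo sapiens) for cytotoxicity, read by sulforhodamine B assay, with a stated time of 48 h, tested at 1 uM (on this read-out lower numbers stand for a stronger effect and higher numbers for a weaker effect at the one concentration tested), where it gives 95%. Among the three compounds measured, this number stands at the top, but only by margins that fall inside the usual scatter, so compound 1 cannot be told apart from the others. Compound 2 `COc1ccc(C(=O)/C=C/c2cc(-c3cc(OC)c(OC)c(OC)c3)n[nH]2)cc1` gives 94% in this assay, and compound 3 `COc1cc(-c2cc(/C=C/C(=O)c3ccc(F)c(F)c3)[nH]n2)cc(OC)c1OC` gives 92%. The corresponding steps are small: a number 1 percentage points lower from compound 1 to compound 2 (within the scatter), a number 3 percentage points lower from compound 1 to compound 3 (within the scatter) and a number 2 percentage points lower from compound 2 to compound 3 (within the scatter). All three compounds therefore show only a weak effect at this concentration.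

Compound 4 `COc1cc(C(=O)/C=C/c2cc(-c3cc(OC)c(OC)c(OC)c3)n[nH]2)cc(OC)c1OC` differs from compound 1 in one place: methoxy in place of hydrogen on an aromatic carbon. The step from compound 1 to compound 2 is the one that bears most directly on this change, since it is the same kind of exchange in the opposite direction, hydrogen in place of methoxy on an aromatic carbon, and it stayed within the scatter. The exchange of the whole aryl group on the carbonyl carbon in the other two steps also moved nothing beyond the scatter. On that basis no step beyond the scatter is expected in this assay for compound 4, and its number is estimated at 94%, within 86% to 100%, which means an expected step of a number 1 percentage points lower from compound 1 to compound 4 (within the scatter).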

Compound 4, a percentage reported as activity, at one concentration (the size of the read-out at that concentration, not a potency): 98%
Compound 4: the middle estimate sits 4 percentage points below what was measured; the range from low to high includes it.
By their numbers in this assay, from the lowest: compounds 3, 2, 1 and 4 (each within the scatter of the next).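

In this assay, methoxy in place of hydrogen on an aromatic carbon, ortho to a methoxy group and meta to a large group, gives a number 3 percentage points higher from compound 1 to compound 4 (within the scatter). The earlier compounds shown here showed a methoxy exchange only in the direction of taking the group away, so this result adds the opposite direction: putting a methoxy on this ring does not produce a stronger effect that can be told apart from compound 1 at the one concentration tested. Nothing available explains this outcome or ties it to any property of the methoxy group.

On these data alone, what stays open is whether this aromatic carbon responds at all, since so far only hydrogen and methoxy have been compared there, and an amine, a hydroxyl, a carboxylic acid or a longer chain such as butoxy could behave quite differently. As far as these compounds go, all four compounds also show only a weak effect at this single concentration, so it remains unknown whether this exchange would make any difference at higher concentrations, where a stronger effect might separate them.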